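Chloro to bromo swap in two related series

The source may hold more compounds than are shown below. What is called first, only, known or untested is meant among the compounds shown, and "the series" means these compounds.

Compound 1 `O=C1C(=O)N(CN2CCN(c3ccnc4cc(Cl)ccc34)CC2)c2cc(Cl)ccc21` is the reference point. In a functional assay on MDA-MB-468 cells (Homo sapiens) for cytotoxicity, read by sulforhodamine B assay, with a stated time of 48 h (a lower number here means a stronger inhibitor of growth, a higher number a weaker inhibitor of growth), compound 1 gives 36600 nM. Compound 2 `O=C1C(=O)N(CN2CCN(c3ccnc4cc(Cl)ccc34)CC2)c2cc(Br)ccc21` carries bromo in place of chloro on an aromatic carbon; in this assay compound 2 gives 35800 nM, and the step of a 1.0-fold lower number from compound 1 to compound 2 (0.01 log units; within the scatter) shows the swap leaves the number essentially where it was.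

Compound 3 `NC(=S)N/N=C1/C(=O)N(CN2CCN(c3ccnc4cc(Cl)ccc34)CC2)c2cccc(Cl)c21` has a different core; how the core of compound 3 differs from the core of compound 1 is not broken down here. In this assay compound 3 gives 57600 nM, within the scatter of both compound 1 and compound 2.

Compound 4 `NC(=S)N/N=C1/C(=O)N(CN2CCN(c3ccnc4cc(Cl)ccc34)CC2)c2cccc(Br)c21` is not yet measured. It carries bromo in place of chloro on an aromatic carbon. This is the same kind of change as that from compound 1 to compound 2, but the place differs: in compound 3 the halogen sits ortho to a fused ring and meta to a fused ring, whereas in compound 1 it sits meta to a fused ring and para to a fused ring.

The step from compound 3 to compound 4 is expected to be a 1.0-fold lower number from compound 3 to compound 4 (0.02 log units; within the scatter) in this assay, because a 1.0-fold lower number from compound 1 to compound 2 (0.01 log units; within the scatter) was flat for the same kind of change. Compound 4 is therefore estimated at 55000 nM, between 28000 nM and 110000 nM.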

Compound 4, concentration for 50% growth inhibition: 40400 nM
Compound 4: the middle estimate sits 1.4-fold (0.13 log units) above what was measured, within the range that was stated.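

In this assay, bromo in place of chloro on an aromatic carbon gives a 1.4-fold lower number from compound 3 to compound 4 (0.15 log units; within the scatter), so the swap leaves the number essentially where it was on this core too. Set side by side, the two steps show no difference between the cores: the same change on two cores in this assay, a 1.0-fold lower number (0.01 log units; within the scatter) from compound 1 to compound 2 and a 1.4-fold lower number (0.15 log units; within the scatter) from compound 3 to compound 4, 1.4-fold (0.14 log units) apart, within the scatter of two such steps. This supports carrying the chloro to bromo swap between these two cores in this assay, but it shows nothing for other halogen swaps or other assays, and the core and the place of the halogen change together in these pairs, so their separate contributions cannot be told apart.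

The compounds shown leave open whether any substituent is needed on this aromatic carbon, as plain hydrogen there is not among them. They also leave open whether groups other than the two halogens, such as methoxy, a nitrile or an amine, would stay as flat on either core.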